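The compounds below may be only part of what the source reports. "The series", "measured", "known", "first", "only" and "open" are said of these compounds alone.

Measured compounds in a functional assay on A549 cells (Homo sapiens), read by MTT assay, with a stated time of 72 h; a higher number here means a weaker inhibitor, a lower number a stronger inhibitor:
- compound 1, `Nc1nc(N)c2c(-c3cc4ccccc4o3)cn([C@@H]3O[C@H](CO)[C@@H](O)[C@H]3O)c2n1`: > 20000 nM
- compound 2, `C#Cc1cn([C@@H]2O[C@H](CO)[C@@H](O)[C@H]2O)c2ncnc(OC)c12`: 8160 nM
- compound 3, `O=c1[nH]cnc2c1c(-c1cccs1)cn2[C@@H]1O[C@H](CO)[C@@H](O)[C@H]1O`: > 20000 nM

For compound 3 the value > 20000 nM is a limit of this assay, not a number. For compound 1 the value > 20000 nM is likewise a limit. Going by the values given here, compound 2 is therefore the only compound in this set with a numeric reading, 8160 nM; the two remaining entries sit at the limit of > 20000 nM in this assay, at which 2 of the 3 values shown sit.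

Compound 4, `COc1ncnc2c1c(-c1cc3ccccc3o1)cn2[C@@H]1O[C@H](CO)[C@@H](O)[C@H]1O`, has not been measured in this assay. It differs from compound 2 in one place: 1-benzofuran-2-yl in place of ethynyl on an aromatic carbon. Among the compounds with values here, no step between measured compounds exists for this change, so the direction rests on the set alone. Compound 1 also carries 1-benzofuran-2-yl and sits at the limit of > 20000 nM in this assay, at which 2 of the 3 values shown sit, though its core differs from that of compound 2 in other places. The expectation is a step toward a weaker inhibitor, a 1.5-fold higher number from compound 2 to compound 4 (0.17 log units; within the scatter), but of a size that may not exceed the scatter. Compound 4 is estimated at 12000 nM, within 3000 nM to 40000 nM, with a real chance that this assay returns only a limit.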

Compound 4, half-maximal inhibitory concentration: 17700 nM
Compound 4: the middle estimate sits 1.5-fold (0.17 log units) below what was measured, and the stated range covers the measured number.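

In this assay, going by these compounds alone, replacing ethynyl with 1-benzofuran-2-yl on this aromatic carbon, two ring bonds from the ring nitrogen, gives the first readable step at this position: a 2.2-fold higher number from compound 2 to compound 4 (0.34 log units; beyond the scatter). The step lies beyond the scatter but is modest, and with 1-benzofuran-2-yl in place the shared core still gives a numeric reading rather than a limit. Compound 1 also carries 1-benzofuran-2-yl, but its core differs in other places, so no step can be read from it, and the set still holds limits, which are not numbers: the limit of > 20000 nM in this assay, at which 2 of the 4 values shown sit.

Two groups on one core give a single step, which cannot separate the effect of ring size from that of any other difference between them. From the compounds shown here alone, how an amine, a carboxylic acid or a longer alkyl chain on this carbon would read in this assay remains open.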